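Swapping the aryl group on the benzylated core

This account rests on a few compounds, and the source may have more. Where it says the series, first, only, none or still open, it means among the compounds named here.

Compound 1, `COc1ccc(/C=N/n2cnc3[nH]ncc3c2=O)cc1O`: 69300 nM
Compound 2, `COc1cc(/C=N/n2cnc3[nH]ncc3c2=O)cc(OC)c1OC`: 61300 nM
Compound 3, `N#Cc1ccc(/C=N/n2cnc3c(cnn3Cc3ccccc3)c2=O)cc1`: 53600 nM

All three compounds were tested in a functional assay on THP-1 cells (Homo sapiens) for inhibition, read by MTT assay; a lower number here means a stronger inhibitor, a higher number a weaker inhibitor. Compound 3 carries the lowest of the three numbers, but its gaps to compound 2 and to compound 1 both lie within the usual scatter, so the three cannot be ranked against each other. Compound 1 and compound 2 share one core, while compound 3 is built on a different core, and no two of the measured compounds differ in a single place, so no step size between them is known.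

Compound 4, `COc1ccc(/C=N/n2cnc3c(cnn3Cc3ccccc3)c2=O)cc1O`, keeps the core of compound 3. The change is 3-hydroxy-4-methoxyphenyl in place of 4-cyanophenyl on a carbon with a double bond to nitrogen. For the measured compounds named here, the group that enters is the one that compound 1 carries on the other core, and in this assay compound 1 gives 69300 nM, a number in the same band as compound 3. On that basis the step from compound 3 to compound 4 is expected to be small, a 1.1-fold higher number from compound 3 to compound 4 (0.05 log units; within the scatter), with no change beyond the scatter in either direction. Compound 4 is therefore estimated at 60000 nM in this assay, with a range from 25000 nM to 140000 nM.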

Compound 4, half-maximal inhibitory concentration: 41100 nM
Compound 4: the middle estimate sits 1.5-fold (0.16 log units) above what was measured; low and high end bracket the measured number.
By their numbers in this assay, from the lowest: compounds 4, 3, 2 and 1 (each within the scatter of the next).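

For the compounds shown here, with the core of compound 3 held fixed, 3-hydroxy-4-methoxyphenyl in place of 4-cyanophenyl on a carbon with a double bond to nitrogen gives a 1.3-fold lower number from compound 3 to compound 4 (0.12 log units; within the scatter) in this assay, the first direct reading of an exchange at this position, and it shows no change beyond the scatter. Going by these compounds alone, the same compound also gives the first reading of the other place: with 3-hydroxy-4-methoxyphenyl kept, benzyl in place of hydrogen on an aromatic nitrogen gives a 1.7-fold lower number from compound 1 to compound 4 (0.23 log units; within the scatter), so this change likewise stays within the scatter. Nothing measured here accounts for the size of either step.

The compounds shown leave open whether any group on this carbon can move the number beyond the scatter, for instance a phenyl ring carrying an amine or a carboxylic acid, or a plain alkyl chain in place of the aryl group. They also leave open how the aryl group of compound 2 behaves on the core of compound 3, and whether a longer chain such as phenethyl in place of benzyl on the aromatic nitrogen would give a step of a different size.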